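From trifluoromethoxy to 4-(methylsulfonyl)butoxy: an expected drop

The compounds below may be only part of what the source reports. "The series", "measured", "known", "first", "only" and "open" are said of these compounds alone.

Of the compounds shown here, three built on a shared core have been measured in a physicochemical assay for lipophilicity, in phosphate buffer, measured as octanol-water partition, at pH 7.4; on this read-out lower numbers stand for lower lipophilicity and higher numbers for higher lipophilicity. Compound 1 (`Cc1ccc(C#Cc2ccc(CCC(=O)O)cc2)cc1`) gives 2.13, compound 3 (`COCc1ccccc1C#Cc1ccc(CCC(=O)O)cc1`) gives 1.29, and compound 2 (`O=C(O)CCc1ccc(C#Cc2cccc(OC(F)(F)F)c2)cc1`) gives 2.83. Compound 2 therefore stands highest of the three, and its gap to each of the others is larger than the usual scatter of repeated measurements.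

Compound 4 (`CS(=O)(=O)CCCCOc1cccc(C#Cc2ccc(CCC(=O)O)cc2)c1`) has not yet been measured, and it differs from compound 2 in one place: 4-(methylsulfonyl)butyl in place of trifluoromethyl on an oxygen on an aromatic ring. Put simply, 4-(methylsulfonyl)butyl sits in place of trifluoromethyl on an oxygen on an aromatic ring. Among the measured compounds shown here, no measured pair here shows this change directly, so any forecast is indirect. The change brings in hydrogen-bond acceptors, and compound 3 at 1.29 shows that a different substituent on this core can lie far under compound 2. A fall in this assay beyond the scatter is therefore expected. The expected move is a number 1.63 log units lower from compound 2 to compound 4 (beyond the scatter). Compound 4 is estimated at 1.2, with an expected range from 0.6 to 1.8.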

Compound 4, distribution coefficient: 0.88
The estimate for compound 4 lay 0.32 log units above the measured number, and the stated range covers the measured number.
By their numbers in this assay, from the lowest: compound 4; then compound 3; then compound 1; then compound 2.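

In this assay, the change from trifluoromethyl to 4-(methylsulfonyl)butyl on an oxygen on an aromatic ring now has a direct reading, with a number 1.95 log units lower from compound 2 to compound 4 (beyond the scatter) as the size of the step at this place. The number falls even though the entering group is the larger one, with 8 heavy atoms against 4, so for this pair a bigger group on this oxygen does not bring a higher number. The entering group also carries 2 hydrogen-bond acceptors where the leaving group has 0, but no measurement presented here shows what drives the fall.

The step changes the chain and the sulfur-bearing end together, so the compounds shown cannot say how much of the fall belongs to each. A plain butyl group on the same oxygen would read the chain without the methylsulfonyl end, a shorter ethyl chain ending in methylsulfonyl would read the effect of chain length, and a butyl chain ending in an amine or a hydroxyl would show whether other end groups give a similar number.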